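The compounds below may be only part of what the source reports. "The series", "measured", "known", "first", "only" and "open" are said of these compounds alone.

Compound 1 `CC(C)c1ccc(-c2nc(SCc3cn(CC(=O)NC(=O)Nc4ccccn4)nn3)nc(Nc3ccccc3Cl)c2C#N)cc1` gives 19700 nM in a functional assay on MGC-803 cells (Homo sapiens) for inhibition, read by MTT assay, with a stated time of 72 h; a higher number here means a weaker inhibitor, a lower number a stronger inhibitor. Compound 2 `CC(C)c1ccc(-c2nc(SCc3cn(CC(=O)NC(=O)Nc4ccccn4)nn3)nc(Nc3ccccc3F)c2C#N)cc1` reaches only the limit of this assay, > 64000 nM, so its standing is a bound rather than a number. The step of an at least 3.2-fold higher number from compound 1 to compound 2 (0.51 log units; beyond the scatter) is the only measured one, and it rests on (the limit of > 64000 nM in this assay, at which 1 of the 2 values shown sits). Compound 3 `Cc1ccc(Nc2nc(SCc3cn(CC(=O)NC(=O)Nc4ccccn4)nn3)nc(-c3ccc(C(C)C)cc3)c2C#N)cc1` differs from compound 2 by 4-methylphenyl in place of 2-fluorophenyl on a nitrogen on an aromatic ring. Within the data shown here, no measured step swaps a fluoro for a methyl or moves from one ring position to another, so the direction is open; the expected step is an at least 2.1-fold lower number from compound 2 to compound 3 (0.32 log units; beyond the scatter), near the scatter. Compound 3 is therefore estimated at 30000 nM, within 8000 nM to 120000 nM.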

Compound 3, half-maximal inhibitory concentration: 3360 nM
Beside the measured number, compound 3's estimate is 8.9-fold (0.95 log units) above it, outside the stated range (below it).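

On a nitrogen on an aromatic ring, 4-methylphenyl gives the lowest number of the three compounds in this assay, a position where the earlier pair held only halogen-bearing rings. Replacing 2-chlorophenyl gives a 5.9-fold lower number from compound 1 to compound 3 (0.77 log units; beyond the scatter), and replacing 2-fluorophenyl gives an at least 19-fold lower number from compound 2 to compound 3 (1.27 log units; beyond the scatter). The second step is a bound and not an exact size: the limit of > 64000 nM in this assay, at which 1 of the 3 values shown sits.

The change alters both the substituent and its place on the ring, so the compounds shown do not separate the two. From the compounds shown here alone, how 2-methylphenyl or 4-chlorophenyl would read at this position stays open.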